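The compounds below may be only part of what the source reports. "The series", "measured", "known", "first", "only" and "open" are said of these compounds alone.

In an ADME assay on MT4 cells (Homo sapiens) for cytotoxicity, read by MTT assay, with a stated time of 5 days (on this read-out lower numbers stand for higher toxicity in this test and higher numbers for lower toxicity in this test), compound 1 (`COc1cc2nc([S+]([O-])CC(=O)Nc3ccc(Cl)cc3)nc(Nc3c(Cl)cc(/C=C/C#N)cc3Cl)c2cc1OC`) gives 14400 nM and compound 2 (`COc1cc2nc([S+]([O-])CC(=O)Nc3cccc(S(N)(=O)=O)c3)nc(Nc3c(Cl)cc(/C=C/C#N)cc3Cl)c2cc1OC`) gives 67800 nM, so compound 2 holds the higher of the two numbers. Among the compounds with values here, the only measured step, a 4.7-fold higher number from compound 1 to compound 2 (0.67 log units; beyond the scatter), put 3-sulfamoylphenyl in place of 4-chlorophenyl on an amide-type nitrogen. Compound 3 (`COc1cc2nc([S+]([O-])CC(=O)Nc3ccc(S(N)(=O)=O)cc3)nc(Nc3c(Cl)cc(/C=C/C#N)cc3Cl)c2cc1OC`) differs from compound 2 in one place: 4-sulfamoylphenyl in place of 3-sulfamoylphenyl on an amide-type nitrogen. In plain words, 4-sulfamoylphenyl takes the place of 3-sulfamoylphenyl, and the two groups have the same atoms, joined differently. The measured step of a 4.7-fold higher number from compound 1 to compound 2 (0.67 log units; beyond the scatter) is a weak guide here, as it exchanged one kind of group for another. Within the data shown here, no measured pair shows a change like this one, so no step beyond the scatter is expected in this assay. The expected change is a 1.2-fold lower number from compound 2 to compound 3 (0.09 log units; within the scatter). Compound 3 is estimated at 55000 nM, within an expected range of 25000 nM to 120000 nM.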

Compound 3, half-maximal cytotoxic concentration: > 189000 nM
Compound 3: only a limit was reported; the forecaster's own chance of this, stated with the estimate: 15%; middle value at least 3.4-fold (0.53 log units) away from the limit.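

In this assay compound 3 gives > 189000 nM as a limit of the assay, not as a number. Moving the sulfamoyl group alone, with no atom gained or lost, produces an at least 2.7-fold higher number from compound 2 to compound 3 (0.44 log units; beyond the scatter) and so shows that where this group sits on the phenyl ring matters on this read-out, which the earlier exchange of one group for another could not show. Sulfamoyl in place of chloro on an aromatic carbon produces an at least 13-fold higher number from compound 1 to compound 3 (1.11 log units; beyond the scatter) as the larger step of the series, and both new steps give only a lower bound on their true size: the limit of > 189000 nM in this assay, at which 1 of the 3 values shown sits.

As far as these compounds go, how far the number for compound 3 lies past the limit stays open. So does whether a carboxylic acid or a methylsulfonyl group on the same aromatic carbon would give a similar number.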